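Shortening tert-butyl to isopropyl at the chain end

The source may hold more compounds than are shown below. What is called first, only, known or untested is meant among the compounds shown, and "the series" means these compounds.

Of the compounds shown here, two sharing one core have been measured in a functional assay on mitochondria from heart for inhibition of peroxisomal acyl-coenzyme A oxidase 1 (Rattus norvegicus); on this read-out higher numbers stand for weaker inhibition and lower numbers for stronger inhibition. Compound 1 `Cc1nc2cc(OC[C@H](O)CN3CCN(Cc4noc(-c5ccc(C(C)(C)C)cc5)n4)CC3)ccc2s1` gives 180 nM. Compound 2 `Cc1nc2cc(OC[C@H](O)CN3CCN(Cc4nc(-c5ccc(C(C)(C)C)cc5)no4)CC3)ccc2s1` gives 570 nM, the higher of the two numbers; its nearest neighbour is compound 1, whose number is lower by an amount beyond the usual scatter. Compound 3 `Cc1nc2cc(OC[C@H](O)CN3CCN(Cc4nc(-c5ccc(C(C)C)cc5)no4)CC3)ccc2s1` has not yet been measured in this assay. It differs from compound 2 in one place: hydrogen in place of methyl on a saturated chain carbon bound to an aromatic carbon and two saturated chain carbons; cut one bond further out, this reads tert-butyl to isopropyl, or 4-(tert-butyl)phenyl to 4-isopropylphenyl. For the measured compounds named here, no measured pair shows what such a change does here, so the expectation rests on compound 2 alone. Only a methyl leaves, and the expected step is small, a 1.2-fold higher number from compound 2 to compound 3 (0.09 log units; within the scatter), quite possibly not beyond the scatter. Compound 3 is therefore estimated at 700 nM in this assay, within a range from 300 nM to 1800 nM.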

Compound 3, half-maximal inhibitory concentration: 1230 nM
Compound 3: the middle estimate sits 1.8-fold (0.24 log units) below what was measured; the range from low to high includes it.
By their numbers in this assay, from the lowest: compound 1; then compound 2; then compound 3.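

In this assay the loss of a single methyl, tert-butyl to isopropyl, gives a 2.2-fold higher number from compound 2 to compound 3 (0.33 log units; beyond the scatter) and so weakens inhibition, modestly but by more than the usual scatter. This pair shows that the end of the 4-(tert-butyl)phenyl group is not indifferent to one carbon: the full tert-butyl goes with the stronger inhibition of the two. The data available offer no explanation for this step.

Going by these compounds, whether the number keeps rising as the group shrinks further, to ethyl or a bare hydrogen, or whether cyclopropyl or a longer chain would restore inhibition, remains open. Also open, on these data alone, is whether isopropyl in place of tert-butyl on compound 1 would shift its number by a similar amount.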